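Removing the Chloro From Compound 1: Expected Cytotoxicity

The source may hold more compounds than are shown below. What is called first, only, known or untested is meant among the compounds shown, and "the series" means these compounds.

Compound 1, `O=C1CSC(c2ccccc2Cl)N1c1nnc(S)s1`: 200000 nM
Compound 2, `CS(=O)(=O)c1ccc(NC(=O)CSc2nnc(N3C(=O)CSC3c3cccc(Cl)c3)s2)cc1`: 113000 nM
Compound 3, `NS(=O)(=O)c1ccc(NC(=O)CSc2nnc(N3C(=O)CSC3c3ccc(Cl)cc3)s2)cc1`: >= 222000 nM

All three were tested in an ADME assay on MT4 cells (Homo sapiens) for cytotoxicity, read by MTT assay, with a stated time of 5 days; on this read-out higher numbers stand for lower toxicity in this test and lower numbers for higher toxicity in this test. Compound 1 gives the higher of the two numbers reported, with compound 2 close by, and the two lie within the usual scatter of each other. For compound 3 only a limit is recorded in this assay, namely (the limit of >= 222000 nM in this assay, at which 1 of the 3 values shown sits). Compound 4, `O=C1CSC(c2ccccc2)N1c1nnc(S)s1`, has not been measured in this assay. It differs from compound 1 by hydrogen in place of chloro on an aromatic carbon. For the measured compounds named here, no measured step of this kind is available, and the change is expected to move the number little, if at all, beyond the scatter. Compound 4 is therefore estimated at 200000 nM, within 90000 nM to 400000 nM, the expected step of no change at the digits printed from compound 1 to compound 4 (within the scatter) being small.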

Compound 4, half-maximal cytotoxic concentration: > 423000 nM
Compound 4 was reported as a limit (the forecaster's own chance of this, stated with the estimate: 35%); middle value at least 2.1-fold (0.32 log units) from the limit.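

In this assay, for the compounds shown here, hydrogen in place of chloro, on an aromatic carbon ortho to a large group, gives an at least 2.1-fold higher number from compound 1 to compound 4 (0.32 log units; beyond the scatter) as the first measured step at this position. Unlike the earlier comparison of values within the scatter, this change moves the number towards lower toxicity in this test by more than the scatter. Compound 4 is recorded only as a limit, so the step has a lower bound but no known size: the limit of > 423000 nM in this assay, at which 1 of the 4 values shown sits.

On these data alone, whether a fluoro, a methoxy or an amine at this place would shift the number in the same way remains open. So does the effect of this change on the larger compounds with the chloro elsewhere on the ring.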